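Saturating the Allyl Chain: From Compound 1 to Compound 4

The source may report more compounds than this note shows. Statements on the series, on what has been measured and on what is new or still open speak of the compounds shown alone.

The compounds here share one core and are compared in a functional assay for antagonist activity at 5-hydroxytryptamine receptor 4 (Cavia porcellus); on this read-out lower numbers stand for lower potency and higher numbers for higher potency (the scale is a negative logarithm). Compound 1 `C=CCn1c(=O)n(C(=O)NCCN2CCN(C)CC2)c2ccccc21` carries an allyl chain. In this assay compound 1 gives only < 6, which is a limit of the assay rather than a measured number. Two relatives with an isopropyl group in place of the allyl chain do return numbers: compound 2 `CCCN1CCN(CCNC(=O)n2c(=O)n(C(C)C)c3ccccc32)CC1` gives 6.89, and compound 3 `CC(C)n1c(=O)n(C(=O)NCCN2CCN(C)CC2)c2cc(F)ccc21`, which also carries a fluorine, gives 6.88. Those two values lie within the usual scatter of each other, so nothing separates them. Compound 1 is the one that sits at the limit of < 6 in this assay, at which 1 of the 3 values shown sits.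

Compound 4 `CCCn1c(=O)n(C(=O)NCCN2CCN(C)CC2)c2ccccc21` differs from compound 1 in one place: ethyl in place of vinyl on a saturated chain carbon bound to an aromatic nitrogen. Within the data shown here, no pair of measured compounds isolates this change, so its size can only be inferred loosely. With the branched isopropyl group in place of the allyl chain, compound 2 reaches 6.89, and a straight propyl chain is expected to land somewhere between the outcome for compound 1 and that for compound 2. The step of a number at least 0.20 log units higher from compound 1 to compound 4 (that floor lies within the scatter) is expected to be modest and upward, though it may not exceed the scatter. Compound 4 is therefore estimated at 6.2, with a range from 5.5 to 6.9.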

Compound 4, negative logarithm of the antagonist equilibrium constant: < 6
Compound 4: only a limit was reported (the forecaster's own chance of this, stated with the estimate: 35%); at least 0.20 log units between middle value and limit.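

In this assay compound 4 gives < 6, a limit of the assay and not a number. Among these compounds, compound 1 stands at the same limit, so no step from allyl to propyl can be read between compound 1 and compound 4. Going by these compounds, whether that change alters potency at all, and by how much, remains open.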